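Working notes: a further chloro step in the series

A few compounds are considered here, and "the series" means these few. Any claim that something is new, unique, unknown or untested is made for them only; others in the source may bear on it.

Measured in a functional assay on NCI-H460 cells (Homo sapiens) for inhibition, read by MTT assay, with a stated time of 24 h, tested at 10 ug/mL; a lower number here means less inhibition of growth, a higher number more inhibition of growth at the concentration tested:
- compound 1 `O=C(CCCCC(S)CCS)Nc1ccccc1`: 8.37%
- compound 2 `O=C(CCCCC(S)CCS)Nc1ccccc1Cl`: 18.2%

Within the data shown here, compound 1 stands within the scatter of compound 2, the only other measured compound, so the two values set no order. Compound 3 `O=C(CCCCC(S)CCS)Nc1cccc(Cl)c1` is not yet measured and departs from compound 1 as follows: chloro in place of hydrogen on an aromatic carbon. Among the measured compounds shown here, the one measured step that bears on this is the same kind of exchange, a number 9.8 percentage points higher from compound 1 to compound 2 (within the scatter). A single step is thin evidence, and it supports no expectation of a change beyond the scatter in this assay. The step expected is a number 5.6 percentage points higher from compound 1 to compound 3 (within the scatter). The estimated value for compound 3 is 14%, with an expected range of 4% to 28%.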

Compound 3, percent growth inhibition at one concentration: "not active" (no number reported)
The entry for compound 3 holds no number; the estimate stays without a comparison.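

Among these compounds, compound 3 is entered as "not active" with no number in this assay so no step from compound 1 to compound 3 can be read. Going by these compounds, how compound 3 stands against compound 1 and compound 2 stays open. No measured evidence bears on this result.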